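Acyl groups on the aromatic amine nitrogen: working notes

This account rests on a few compounds, and the source may have more. Where it says the series, first, only, none or still open, it means among the compounds named here.

Values from a functional assay on KB cells (Homo sapiens) for cytotoxicity (on this read-out lower numbers stand for stronger inhibition and higher numbers for weaker inhibition), for the series are as follows
- compound 1 `COc1ccc(S(=O)(=O)N2CCc3cccc(NC(=O)c4cccs4)c32)cc1` at 47 nM
- compound 2 `COc1ccc(S(=O)(=O)N2CCc3cccc(NC(C)=O)c32)cc1` at 89 nM
- compound 3 `COc1ccc(S(=O)(=O)N2CCc3cccc(N)c32)cc1` at 2800 nM
- compound 4 `COc1ccc(S(=O)(=O)N2CCc3cccc(NC(=O)N(C)c4ccccc4)c32)cc1` not yet measured

Compound 3 (2800 nM) gives the highest number of the three and so the weakest inhibition. Going on to compound 4 puts methyl(phenyl)carbamoyl in place of hydrogen on a nitrogen on an aromatic ring.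

Among the measured compounds shown here, two measured steps bear on this change when read in reverse. Both a 60-fold higher number from compound 1 to compound 3 (1.78 log units; beyond the scatter) and a 31-fold higher number from compound 2 to compound 3 (1.50 log units; beyond the scatter) replace a carbonyl-bearing group on that nitrogen with hydrogen, and both are large. For the measured compounds named here, the group on the carbonyl carbon made no difference beyond the scatter in the one comparison available (a 1.9-fold higher number from compound 1 to compound 2 (0.28 log units; within the scatter)). Going by the values given here, no carbamoyl example has been measured, so the range is kept wide.

A large fall in the number is expected in this assay (a 35-fold lower number from compound 3 to compound 4 (1.54 log units; beyond the scatter)). Compound 4 is estimated at 80 nM in the expected range (from 20 nM to 400 nM).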

Compound 4, half-maximal inhibitory concentration: > 10000 nM
Compound 4: a limit, no number; the forecaster's own chance of this, stated with the estimate: 3%; middle value at least 120-fold (2.09 log units) away from the limit.
By their numbers in this assay, from the lowest: compounds 1 and 2 (each within the scatter of the next); then compound 3. At a limit, above all of these: compound 4.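

In this assay, compound 4 gives a limit and not a number: the limit of > 10000 nM in this assay, at which 1 of the 4 values shown sits. A carbonyl-bearing group on the nitrogen on an aromatic ring therefore does not by itself give a low number, since the group on the carbonyl carbon now matters: an at least 110-fold higher number from compound 2 to compound 4 (2.05 log units; beyond the scatter) and an at least 210-fold higher number from compound 1 to compound 4 (2.32 log units; beyond the scatter), where the swap of thiophen-2-yl for methyl stayed within the scatter (a 1.9-fold higher number from compound 1 to compound 2 (0.28 log units; within the scatter)). Compound 4 goes against the reading drawn from compounds 1 and 2, and it also lies past the free amine: an at least 3.5-fold higher number from compound 3 to compound 4 (0.55 log units; beyond the scatter).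

Open, on these data alone, is which part of methyl(phenyl)amino goes with this loss. A phenylamino, a methylamino or a dimethylamino group on the same carbonyl carbon could separate the methyl from the phenyl ring.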